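Swapping the aryl group of compound 3 for a thiophene

The source may hold more compounds than are shown below. What is called first, only, known or untested is meant among the compounds shown, and "the series" means these compounds.

Measured in a functional assay on MOLT-4 cells (Homo sapiens) for antiproliferative activity; on this read-out higher numbers stand for weaker inhibition and lower numbers for stronger inhibition:
- compound 1 `COc1cc(C(=O)c2sc(-c3ccc([N+](=O)[O-])cc3)cc2N)cc(OC)c1OC`: 110 nM
- compound 2 `COc1cc(C(=O)c2sc(-c3cccc([N+](=O)[O-])c3)cc2N)cc(OC)c1OC`: 7.5 nM
- compound 3 `COc1cc(C(=O)c2sc(-c3ccccc3Cl)cc2N)cc(OC)c1OC`: 17 nM

Among these three numbers, compound 3 stands in the middle at 17 nM. Only compound 2 has a lower number, and only compound 1 has a higher one.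

The next compound is compound 4 `COc1cc(C(=O)c2sc(-c3cccs3)cc2N)cc(OC)c1OC`, which has not yet been measured. It carries thiophen-2-yl in place of 2-chlorophenyl on an aromatic carbon, next to the ring sulfur: thiophen-2-yl in place of 2-chlorophenyl on an aromatic carbon.

Three measured steps change the group at this same place. The first is large, a 15-fold lower number from compound 1 to compound 2 (1.17 log units; beyond the scatter). The second is modest, a 6.5-fold lower number from compound 1 to compound 3 (0.81 log units; beyond the scatter). The third is also modest, a 2.3-fold higher number from compound 2 to compound 3 (0.36 log units; beyond the scatter). None of them involves thiophen-2-yl, so they show how sensitive this place is but not which way the new group will move the number. Two of the three groups give low numbers, and 4-nitrophenyl is the exception.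

A small rise in this assay is expected, estimated as a 1.5-fold higher number from compound 3 to compound 4 (0.17 log units; within the scatter), and it may not clear the usual scatter. The estimate for compound 4 is 25 nM, with an expected range of 7 nM to 90 nM.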

Compound 4, half-maximal inhibitory concentration: 8.9 nM
Compound 4: the middle estimate sits 2.8-fold (0.45 log units) above what was measured; the range from low to high includes it.
By their numbers in this assay, from the lowest: compounds 2, 4 and 3 (each within the scatter of the next, the first and the last beyond it); then compound 1.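

In this assay thiophen-2-yl at this place keeps the number low, with a 1.9-fold lower number from compound 3 to compound 4 (0.28 log units; within the scatter) and a 1.2-fold higher number from compound 2 to compound 4 (0.07 log units; within the scatter) both inside the usual scatter, so the new compound cannot be separated from either of the two earlier compounds with low numbers. Within the data shown here, the only clear difference is a 12-fold lower number from compound 1 to compound 4 (1.09 log units; beyond the scatter) and it marks 4-nitrophenyl as the one group of these four that stands apart. A six-membered aromatic ring of carbon is therefore not required for a low number here: a five-membered aromatic ring with one sulfur does as well as 2-chlorophenyl and 3-nitrophenyl.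

Still open, from the compounds shown here alone, is how much this place tolerates beyond aromatic rings of this kind, for example whether furan-2-yl, with oxygen in the ring, or a cyclohexyl ring, which is not aromatic, would also give a low number. Nothing available bears on what lies behind these numbers, so the similar results for such different groups stay a plain observation.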